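Methyl for Hydrogen on an Oxygen: Cytotoxicity Expectation

The source may hold more compounds than are shown below. What is called first, only, known or untested is meant among the compounds shown, and "the series" means these compounds.

Compound 1, `CC(C)(CNC(=O)c1ccc2ccccc2c1)CC1=C(O)C(=O)c2ccccc2C1=O`: 9000 nM
Compound 2, `COC1=C(CC(C)(C)CNC(=O)c2ccc3ccccc3c2)C(=O)c2ccccc2C1=O`: 34100 nM
Compound 3, `COc1cc(C(=O)NCC(C)(C)CC2=C(O)C(=O)c3ccccc3C2=O)c(OC)c2ccccc12`: 47000 nM

Of the compounds shown here, three have been tested in a functional assay on KB cells (Homo sapiens) for cytotoxicity, read by resazurin assay, with a stated time of 3 days; a higher number here means a weaker inhibitor, a lower number a stronger inhibitor. Compound 2 differs from compound 1 by methyl in place of hydrogen on an oxygen on an unsaturated carbon, and that change produced a 3.8-fold higher number from compound 1 to compound 2 (0.58 log units; beyond the scatter). Compound 3 carries a different core; the difference between the two cores is not broken down here. Compound 3 and compound 2 give numbers that lie within the scatter of each other, while compound 3 stands well beyond the scatter from compound 1.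

Compound 4, `COC1=C(CC(C)(C)CNC(=O)c2cc(OC)c3ccccc3c2OC)C(=O)c2ccccc2C1=O`, has not yet been measured in this assay. It differs from compound 3 by methyl in place of hydrogen on an oxygen on an unsaturated carbon, the same change, at the same place, as that between compound 1 and compound 2. Compound 4 is expected to show a 3.2-fold higher number from compound 3 to compound 4 (0.50 log units; beyond the scatter) in this assay, a step of about the earlier size, because the same change gave a 3.8-fold higher number from compound 1 to compound 2 (0.58 log units; beyond the scatter). This rests on a single earlier instance and on compound 3 already standing high, so the assay may report only a limit. Compound 4 is estimated to give 150000 nM, with a likely range from 50000 nM to 400000 nM.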

Compound 4, half-maximal inhibitory concentration: 41200 nM
The estimate for compound 4 lay 3.6-fold (0.56 log units) above the measured number; measured number outside the range, below it.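

In this assay, among these compounds, the swap of hydroxy to methoxy on the oxygen of the core of compound 3 gave a 1.1-fold lower number from compound 3 to compound 4 (0.06 log units; within the scatter), so on this core the change left no step that can be told from the scatter. Set beside the earlier pair, the change does not carry across with the same size, and the step seen on one core could not be relied on for the other: the same change on two cores in this assay, a 3.8-fold higher number (0.58 log units; beyond the scatter) from compound 1 to compound 2 and a 1.1-fold lower number (0.06 log units; within the scatter) from compound 3 to compound 4, 4.3-fold (0.64 log units) apart, beyond the scatter of two such steps. This shows that the size of the step depends on the core in this series, but it does not show which part of the difference between the two cores is responsible, and two pairs give no rule for any further core.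

The compounds shown carry only hydrogen or methyl on this oxygen, so what a longer chain such as ethyl, or an acetyl group, would do there remains open. Also open, on these data alone, is how an amine or a carboxylic acid elsewhere on these molecules would behave in this assay.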